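From benzoyl to (trifluoromethyl)carbonyl on compound 1

A few compounds are considered here, and "the series" means these few. Any claim that something is new, unique, unknown or untested is made for them only; others in the source may bear on it.

Compound 1 (`O=C(c1ccccc1)N1CCC(C(=O)N2N=CCC2c2ccccc2)CC1`) gives 1.72 h in an ADME assay on microsomes (Homo sapiens) for metabolic stability (a lower number here means that the compound disappears faster, a higher number that the compound lasts longer), and holds the highest of the two plain numbers in the series. The nearest number belongs to compound 2 (`C[C@@H]1C=NN(C(=O)C(C)(C)C)[C@@H]1c1ccccc1`), which at 0.45 h lies lower than compound 1 by more than the usual scatter. Compound 3 (`CC(C)(C)C(=O)N1N=CCC1c1cocn1`) has no plain number: its > 1.5 h is a limit of the assay.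

Compound 4 (`O=C(C1CCN(C(=O)C(F)(F)F)CC1)N1N=CCC1c1ccccc1`) keeps the core of compound 1 and carries trifluoromethyl in place of phenyl on a carbonyl carbon. Cut one bond further out, the same difference reads benzoyl to (trifluoromethyl)carbonyl. Among the compounds with values here, no two measured compounds differ in one place, so the series offers no measured size for this change.

In this assay the expectation rests on compound 1 at 1.72 h and is for no step beyond the scatter. The estimated step of a 1.2-fold lower number from compound 1 to compound 4 (0.09 log units; within the scatter) leans slightly downward and stays within the scatter. For compound 4 the half-life is expected at 1.4 h with an estimated range from 0.6 h to 3 h in this series.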

Compound 4, half-life: > 1.5 h
Compound 4: a limit, no number; the forecaster's own chance of this, stated with the estimate: 30%; middle value at least 1.0-fold (0.02 log units) from the limit.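

In this assay, compound 4 gives > 1.5 h, a limit and not a number. No step from compound 1 to compound 4 can therefore be read, because the comparison stops at the assay limit: the limit of > 1.5 h in this assay, at which 2 of the 4 values shown sit.

The compounds shown leave open whether trifluoromethyl in place of phenyl on a carbonyl carbon changes the half-life at all, and in which direction.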